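This account rests on a few compounds, and the source may have more. Where it says the series, first, only, none or still open, it means among the compounds named here.

Compound 1 `Clc1cc(-c2ccn3c(CC4CC4)nnc3c2Cl)ccc1OC1CCOCC1` gives 224 nM in a functional assay on cells for positive allosteric modulation of metabotropic glutamate receptor 2 (Homo sapiens), read by scintillation counting and GTPgammaS binding, with a stated time of 30 min; on this read-out lower numbers stand for an effect already at smaller amounts and higher numbers for an effect only at larger amounts of compound.
Compound 2 `FC(F)(F)c1c(-c2ccc(OC3CCOCC3)c(Cl)c2)ccn2c(CC3CC3)nnc12` gives 38 nM in this assay.

Among the compounds with values here, compound 2 stands lowest of the two numbers; the only measured step, a 5.9-fold lower number from compound 1 to compound 2 (0.77 log units; beyond the scatter), arose from a trifluoromethyl in place of chloro. Compound 3 `FC(F)(F)c1c(-c2ccc(NC3CCOCC3)c(Cl)c2)ccn2c(CC3CC3)nnc12` differs from compound 2 in a different place: (oxan-4-yl)amino in place of (oxan-4-yl)oxy on an aromatic carbon. Within the data shown here, no measured step touches this kind of exchange, so nothing here points to a clear direction, and only a step within the usual scatter, a 1.3-fold higher number from compound 2 to compound 3 (0.12 log units; within the scatter), is expected. Compound 3 is therefore estimated at 50 nM, with a range from 15 nM to 160 nM.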

Compound 3, half-maximal effective concentration: 18.6 nM
The estimate for compound 3 lay 2.7-fold (0.43 log units) above the measured number, within the range that was stated.
By their numbers in this assay, from the lowest: compound 3; then compound 2; then compound 1.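

With (oxan-4-yl)amino in place of (oxan-4-yl)oxy, this assay shows a 2.0-fold lower number from compound 2 to compound 3 (0.31 log units; beyond the scatter). So the aromatic carbon ortho to the chloro group is a second place where an exchange moves the number beyond the scatter, even though the heavy-atom count stays the same and the entering group adds a hydrogen-bond donor. Nothing measured here bears on the cause of this step.

As far as these compounds go, whether the hydrogen on the amino nitrogen matters remains open, and a methylamino link would probe this. From the compounds shown here alone, it is also open whether the same exchange would have a similar effect with chloro in place of trifluoromethyl.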